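Swapping chloromethyl for methoxycarbonyl on two related cores

This account rests on a few compounds, and the source may have more. Where it says the series, first, only, none or still open, it means among the compounds named here.

Compound 1 `CN1CCN(c2ccc(C3=NN(C(=O)CCCl)C(c4ccc(N(C)C)cc4)C3)cc2)CC1` carries a 4-methylpiperazin-1-yl group; in a functional assay on MDA-MB-231 cells (Homo sapiens) for inhibition, read by sulforhodamine B assay, tested at 10 uM (on this read-out higher numbers stand for more inhibition at the one concentration tested (going by the name of the read-out) and lower numbers for less inhibition), compound 1 gives 2.4%. Compound 2 `COC(=O)CC(=O)N1N=C(c2ccc(N3CCN(C)CC3)cc2)CC1c1ccc(N(C)C)cc1` differs from it by methoxycarbonyl in place of chloromethyl on a saturated chain carbon bound to a carbonyl carbon, and in this assay compound 2 gives -0.4%, a step of a number 2.8 percentage points lower from compound 1 to compound 2 (within the scatter). Compound 3 `CN(C)c1ccc(C2CC(c3ccc(-n4cncn4)cc3)=NN2C(=O)CCCl)cc1` differs from compound 1 by 1H-1,2,4-triazol-1-yl in place of 4-methylpiperazin-1-yl on an aromatic carbon; in this assay compound 3 gives 3.7%, with a number 1.3 percentage points higher from compound 1 to compound 3 (within the scatter). Compound 4 `COC(=O)CC(=O)N1N=C(c2ccc(-n3cncn3)cc2)CC1c1ccc(N(C)C)cc1` has not been measured. It stands to compound 3 as compound 2 stands to compound 1, through (methoxycarbonyl in place of chloromethyl on a saturated chain carbon bound to a carbonyl carbon), at the same place in both pairs, so the change is the same one. Because the earlier step measured a number 2.8 percentage points lower from compound 1 to compound 2 (within the scatter), a similarly small step is expected for compound 4, namely a number 2.7 percentage points lower from compound 3 to compound 4 (within the scatter). Compound 4 is thus estimated at 1%, between -8% and 10%.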

Compound 4, a percentage reported as inhibition, at one concentration (the size of the read-out at that concentration, not a potency): 6.8%
Compound 4: the middle estimate sits 5.8 percentage points below what was measured, within the range that was stated.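

In this assay, methoxycarbonyl in place of chloromethyl gives a number 3.1 percentage points higher from compound 3 to compound 4 (within the scatter), and the two cores agree within the scatter: the same change on two cores in this assay, a number 2.8 percentage points lower (within the scatter) from compound 1 to compound 2 and a number 3.1 percentage points higher (within the scatter) from compound 3 to compound 4, 5.9 percentage points apart, within the scatter of two such steps. Likewise, 1H-1,2,4-triazol-1-yl in place of 4-methylpiperazin-1-yl gives a number 7.2 percentage points higher from compound 2 to compound 4 (within the scatter), and this change also agrees across the two cores within the scatter: the same change on two cores in this assay, a number 1.3 percentage points higher (within the scatter) from compound 1 to compound 3 and a number 7.2 percentage points higher (within the scatter) from compound 2 to compound 4, 5.9 percentage points apart, within the scatter of two such steps. Since every one of these steps lies within the scatter, the pairs show no readable effect of either change on either core, and they do not show that a step of real size would carry from one core to another.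

The compounds shown leave open whether an amine, a carboxylic acid or a longer chain in place of chloromethyl would give a larger number in this assay. They also leave open whether a morpholine in place of 4-methylpiperazin-1-yl would do so.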